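Swapping one group on the amide of compound 3

This account rests on a few compounds, and the source may have more. Where it says the series, first, only, none or still open, it means among the compounds named here.

Of the compounds shown here, three have numbers so far in a functional assay on HCT-116 cells (Homo sapiens) for inhibition, read by sulforhodamine B assay, with a stated time of 3 days (a higher number here means a weaker inhibitor, a lower number a stronger inhibitor), for now. Compound 1 (`O=C1Nc2ccc(F)cc2/C1=C\C(=O)c1ccc(O)cc1F`) gives 1070 nM in this test, and compound 2 (`O=C1Nc2ccccc2/C1=C\C(=O)c1c[nH]c2ccccc12`) gives 860 nM in the same test. Compound 3 (`COc1ccc(C(=O)Nc2ccc3c(c2)/C(=C/Nc2cccc(N4CCN(C)CC4)c2)C(=O)N3)cc1`) gives 2010 nM as its number. That number lies within the usual scatter of compound 1, so those two cannot be told apart. Compound 2 stands lower than compound 3 by more than the scatter, which makes it the stronger inhibitor of that pair.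

Compound 4 (`CN1CCN(c2cccc(N/C=C3\C(=O)Nc4ccc(NC(=O)c5c(Cl)cccc5Cl)cc43)c2)CC1`) has not been measured yet. It differs from compound 3 in one place: 2,6-dichlorophenyl in place of 4-methoxyphenyl on a carbonyl carbon that also carries an amide-type nitrogen (2,6-dichlorophenyl in place of 4-methoxyphenyl on a carbonyl carbon). For the measured compounds named here, no two measured compounds differ in a single place, so the data show nothing about what this swap does. The expectation therefore starts from compound 3 at 2010 nM as the nearest measured relative, and no change beyond the scatter is expected. The estimated move (a 1.3-fold lower number from compound 3 to compound 4 (0.13 log units; within the scatter)) stays small. For compound 4 the expected value is 1500 nM with an estimated range from 500 nM to 4500 nM until the measurement arrives.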

Compound 4, half-maximal inhibitory concentration: 2280 nM
Compound 4: the middle estimate sits 1.5-fold (0.18 log units) below what was measured; the range from low to high includes it.
By their numbers in this assay, from the lowest: compounds 2, 1, 3 and 4 (each within the scatter of the next, the first and the last beyond it).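

In this assay, for the compounds shown here, putting 2,6-dichlorophenyl in place of 4-methoxyphenyl on the carbonyl carbon gives a 1.1-fold higher number from compound 3 to compound 4 (0.05 log units; within the scatter) and is the first single-place comparison in this set, so the two compounds cannot be told apart. At this position, then, one aromatic ring of eight heavy atoms can stand in for another even though the substituents on the ring differ completely: the methoxy oxygen, with its one hydrogen-bond acceptor, leaves, and two chlorines, with no acceptor, enter. No supporting data bear on why this exchange leaves the reading within the scatter.

Going by these compounds, both groups compared here are substituted phenyl rings, so it remains open whether this position would accept something of another kind on the carbonyl carbon, such as a morpholine, a carboxylic acid or a longer alkyl chain. On these data alone, it is also open how a phenyl ring carrying a single chlorine or no substituent at all would compare, and whether the same exchange would read the same way if the rest of the molecule were different.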